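A few compounds are considered here, and "the series" means these few. Any claim that something is new, unique, unknown or untested is made for them only; others in the source may bear on it.

Working notes on the series. The shared core carries a chloro group and two amino substituents; compound 1 `C[C@@H](Nc1nc(Cl)nc(NC(C)(C)C)n1)c1ccccc1`, compound 2 `CC(C)Nc1nc(Cl)nc(N[C@@H](C)c2ccccc2)n1` and compound 3 `CC(C)Nc1nc(Cl)nc(N[C@H](C)c2ccccc2)n1` vary these. In an ADME assay on the whole organism for inhibition, with Oryza sativa as the target, with a stated time of 4 days (on this read-out lower numbers stand for stronger inhibition and higher numbers for weaker inhibition), compound 1 gives 9330 nM, compound 2 gives 23400 nM and compound 3 gives 5370 nM, so compound 2 stands at the highest number of the three measured. The step of a 4.4-fold lower number from compound 2 to compound 3 (0.64 log units; beyond the scatter) rests on (the fact that compounds 2 and 3 differ only in the configuration as drawn); the step of a 1.7-fold lower number from compound 1 to compound 3 (0.24 log units; within the scatter) concerns the other amino substituent. Compound 4 `CCCN(C)c1nc(Cl)nc(N[C@@H](C)c2ccccc2)n1` differs from compound 2 by methyl(propyl)amino in place of isopropylamino on an aromatic carbon. Neither measured step touches this substituent, so no change beyond the scatter is expected: the step of a 1.1-fold higher number from compound 2 to compound 4 (0.03 log units; within the scatter) is the estimate. Compound 4 is expected to give 25000 nM, within 8000 nM to 80000 nM, pending measurement.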

Compound 4, half-maximal inhibitory concentration: 5500 nM
Estimate against measurement, compound 4: 4.5-fold (0.66 log units) above; measured number outside the range, below it.
By their numbers in this assay, from the lowest: compounds 3, 4 and 1 (each within the scatter of the next); then compound 2.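

Within the data shown here, the position on the aromatic carbon opposite the ring nitrogen, untouched by the earlier steps, proves responsive: methyl(propyl)amino in place of isopropylamino gives a 4.3-fold lower number from compound 2 to compound 4 (0.63 log units; beyond the scatter). This holds with the stereocentre drawn S, and the entering group has 0 hydrogen-bond donors where the leaving group has 1. Nothing at hand accounts for this step.

Open, as far as these compounds go, is whether the donor count or the chain carries the step, which propylamino or dimethylamino at this position could separate. Also open, from the compounds shown here alone, is whether the same change acts with the stereocentre drawn R.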